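The compounds below may be only part of what the source reports. "The series", "measured", "known", "first", "only" and "open" are said of these compounds alone.

Compound 1 `Nc1cc(N)c2nc(-c3ccccc3)c(Oc3ccc(Cl)c(Cl)c3)nc2c1`: < 100000 nM
Compound 2 `CCOC(=O)[C@H](CCC(=O)O)NC(=O)c1ccc(Sc2nc3cc(N)cc(N)c3nc2-c2ccccc2)cc1`: < 100000 nM
Compound 3 `CCOC(=O)[C@H](CCC(=O)O)NC(=O)c1ccc(CNc2nc3cc(N)cc(N)c3nc2-c2ccccc2)cc1`: < 100000 nM

Of the compounds shown here, three sharing one core have been tested in a functional assay on CCRF-CEM cells (Homo sapiens) for inhibition, read by sulforhodamine B assay, with a stated time of 48 h; a higher number here means a weaker inhibitor of growth, a lower number a stronger inhibitor of growth. For compound 1 the value < 100000 nM is a limit of this assay and not a number. For compound 2 the value < 100000 nM is likewise a limit. For compound 3 the value < 100000 nM is also a limit. Among the measured compounds shown here, compound 1 therefore stands nowhere in particular on these numbers: all three values sit at the limit of < 100000 nM in this assay, at which 3 of the 3 values shown sit, and no step between measured compounds can be sized, so no measured change is known.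

The piece now turns to compound 4 `COc1ccc(Sc2nc3cc(N)cc(N)c3nc2-c2ccccc2)cc1`, which is yet to be measured in this assay. Compared with compound 1, compound 4 carries (4-methoxyphenyl)sulfanyl in place of 3,4-dichlorophenoxy on an aromatic carbon.

For the measured compounds named here, with no measured step, the size of the change from compound 1 to compound 4 cannot be read from the numbers; with compound 1 only at a limit, the expectation is no more than that compound 4 too falls within that limit. The step from compound 1 to compound 4 that this estimate means is a step that the limit leaves unreadable from compound 1 to compound 4, and it is only an expectation. Compound 4 is estimated at 30000 nM, within a range from 3000 nM to 100000 nM.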

Compound 4, concentration for total growth inhibition: 8320 nM
Estimate against measurement, compound 4: 3.6-fold (0.56 log units) above, and the stated range covers the measured number.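

The step from compound 1 to compound 4 cannot be read, because compound 1 is known only through a limit of the assay and not a number: the limit of < 100000 nM in this assay, at which 3 of the 4 values shown sit.

On these data alone, whether, and by how much, the result in this assay changes when (4-methoxyphenyl)sulfanyl replaces 3,4-dichlorophenoxy on the shared core remains open.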